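This account rests on a few compounds, and the source may have more. Where it says the series, first, only, none or still open, it means among the compounds named here.

Working notes on the series.

Compound 3 `CCOc1c(-c2occ(C)c2CO)ccc2c1CCCC2(C)C` gives 14.3 uM in a functional assay on ZR-75-1 cells (Homo sapiens) for cytotoxicity, read by sulforhodamine B assay, with a stated time of 3 days; a lower number here means that less compound is needed, a higher number that more compound is needed for the effect. Compound 2 `COCc1c(C)coc1-c1ccc2c(c1OC)CCCC2(C)C` gives 14.3 uM in this assay, level with compound 3 at the digits shown, within the scatter; together these are the highest of the three numbers. Compound 1 `Cc1coc(-c2ccc3c(c2O)CCCC3(C)C)c1C(=O)O` gives 1.7 uM in this assay, a lower number than compound 3, beyond the scatter.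

Compound 4 `Cc1coc(-c2ccc3c(c2O)CCCC3(C)C)c1CO` is not yet measured. It differs from compound 3 in one place: hydrogen in place of ethyl on an oxygen on an aromatic ring. Compound 4 thus shares the hydroxy of compound 1 and the hydroxymethyl of compound 3.

Compound 4 is expected to give a lower number than compound 3, with a step of a 3.6-fold lower number from compound 3 to compound 4 (0.55 log units; beyond the scatter), because compound 1 with hydroxy gives 1.7 uM. The estimate for compound 4 in this assay is 4 uM, within 1.5 uM to 10 uM.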

Compound 4, concentration for half-maximal effect: 25.5 uM
Beside the measured number, compound 4's estimate is 6.4-fold (0.80 log units) below it; measured number outside the range, above it.
By their numbers in this assay, from the lowest: compound 1; then compounds 2, 3 and 4 (each within the scatter of the next).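

In this assay, ethoxy to hydroxy on the oxygen on the aromatic ring, with hydroxymethyl kept, gives a 1.8-fold higher number from compound 3 to compound 4 (0.25 log units; within the scatter), so the hydroxy alone does not bring the low number of compound 1. Hydroxymethyl in place of carboxy on an aromatic carbon gives a 15-fold higher number from compound 1 to compound 4 (1.18 log units; beyond the scatter), the only step shown here that lies beyond the scatter. Nothing available accounts for either step.

On these data alone, whether a primary amide or a methyl ester in place of carboxy keeps the low number remains open. Also open, as far as these compounds go, is whether a chain longer than ethyl on that oxygen changes the number.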